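A few compounds are considered here, and "the series" means these few. Any claim that something is new, unique, unknown or untested is made for them only; others in the source may bear on it.

Compound 1 `Cc1nnn(Cc2ccc(C(F)(F)F)cc2)c1C(=O)N[C@@H](C)c1ccc(C(=O)O)cc1`: > 10000 nM in a functional assay on CHO cells for antagonist activity at prostaglandin E2 receptor EP4 subtype (Homo sapiens), read by calcium flux, with a stated time of 15 min; a higher number here means a weaker inhibitor, a lower number a stronger inhibitor 
Compound 2 `C[C@H](NC(=O)c1c(-c2ccccc2)nnn1Cc1ccccc1)c1ccc(C(=O)O)cc1`: 647 nM 
Compound 3 `COc1ccc(Cn2nnc(-c3ccccc3)c2C(=O)N[C@@H](C)c2ccc(C(=O)O)cc2)cc1F`: 29.8 nM 

Compound 1 gives only a limit in this assay, (the limit of > 10000 nM in this assay, at which 1 of the 3 values shown sits), and so has no number of its own; it stands at the weak end of the three. Among the measured compounds shown here, the one measured step, a 22-fold lower number from compound 2 to compound 3 (1.34 log units; beyond the scatter), concerns a change on the saturated chain carbon bound to an aromatic nitrogen and so does not bear on the change at hand. Compound 4 `C=CCc1nnn(Cc2ccc(C(F)(F)F)cc2)c1C(=O)N[C@@H](C)c1ccc(C(=O)O)cc1` differs from compound 1 by vinyl in place of hydrogen on a saturated chain carbon bound to an aromatic carbon. For the measured compounds named here, no measured step speaks to this change, so the expected step from compound 1 to compound 4 is none beyond the scatter, a step that the limit leaves unreadable from compound 1 to compound 4. Compound 4 is therefore expected to lie near 12000 nM, in the range 3000 nM to 50000 nM, most likely again as a limit.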

Compound 4, half-maximal inhibitory concentration: > 1000 nM
Compound 4: a limit, no number; the forecaster's own chance of this, stated with the estimate: 70%; the middle value does not contradict the limit.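

Compound 1 and compound 4 each give only a limit, so no step can be read between them. The compounds shown leave open whether allyl in place of methyl changes inhibition at all.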